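The source may hold more compounds than are shown below. What is called first, only, known or untested is meant among the compounds shown, and "the series" means these compounds.

Compound 1 `Cc1ccsc1-c1cc(-c2ccco2)cc(-c2ccc(Cl)cc2)n1`: 24500 nM
Compound 2 `Cc1ccc(-c2cc(-c3ccoc3)cc(-c3ccc(Cl)s3)n2)o1`: 26500 nM

In a functional assay on HeLa cells (Homo sapiens) for cytotoxicity, read by ELISA, with a stated time of 4 days (a higher number here means a weaker inhibitor, a lower number a stronger inhibitor), compound 2 gives 26500 nM. That is within the scatter of repeated measurements of compound 1 at 24500 nM, so the two cannot be told apart here. Compound 3 `Clc1ccc(-c2cc(-c3ccoc3)cc(-c3ccccc3Cl)n2)s1` has not yet been measured. It carries 2-chlorophenyl in place of the 5-methylfuran-2-yl of compound 2, on an aromatic carbon next to the ring nitrogen (2-chlorophenyl in place of 5-methylfuran-2-yl on an aromatic carbon). Among the measured compounds shown here, no two measured compounds differ in only one place, so the data give no direct size for this change. For the measured compounds named here, the only guide is that compound 1 at 24500 nM and compound 2 at 26500 nM lie so close despite their different groups. No step beyond the scatter is therefore expected in this assay. The estimated step is a 1.3-fold lower number from compound 2 to compound 3 (0.12 log units; within the scatter). For compound 3 the expected value is 20000 nM, with an estimated range of 8000 nM to 50000 nM.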

Compound 3, half-maximal inhibitory concentration: 19000 nM
Beside the measured number, compound 3's estimate is 1.1-fold (0.02 log units) above it; measured number inside the range.
By their numbers in this assay, from the lowest: compounds 3, 1 and 2 (each within the scatter of the next).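

Among the compounds shown here, this is the first direct comparison at this position. On the aromatic carbon next to the ring nitrogen, 2-chlorophenyl in place of 5-methylfuran-2-yl gives a 1.4-fold lower number from compound 2 to compound 3 (0.14 log units; within the scatter) in this assay. The two groups therefore cannot be told apart here, even though one is a five-membered aromatic ring counted with a hydrogen-bond acceptor and the other is a six-membered aromatic ring of carbon only, counted with none. No measurement on hand explains this result.

Going by these compounds, whether a different kind of group at this position, such as an amine, a carboxylic acid or a longer chain, would give a step beyond the scatter stays open. This single step also cannot show whether the same exchange would behave alike with other groups on the shared core.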